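Trading a Methoxyphenyl Arm for a Phenylethenyl Arm

The compounds below may be only part of what the source reports. "The series", "measured", "known", "first", "only" and "open" are said of these compounds alone.

Compound 1 `CC(=O)c1cc(-c2ccc(F)cc2)cc2cc(-c3ccccc3)[nH]c12`: 98.3%
Compound 2 `COc1ccc(-c2cc(C(C)=O)c3[nH]c(-c4ccccc4)cc3c2)cc1`: 99.2%

In a functional assay on MCF7 cells (Homo sapiens) for cytotoxicity, read by MTT assay, with a stated time of 2 days, tested at 0.1 uM (on this read-out lower numbers stand for a stronger effect and higher numbers for a weaker effect at the one concentration tested), compound 2 gives 99.2%, and compound 1 gives 98.3%; the two lie within the scatter of each other, so neither can be set apart. Compound 3 `CC(=O)c1cc(/C=C/c2ccccc2)cc2cc(-c3ccccc3)[nH]c12` differs from compound 2 by 2-phenylethenyl in place of 4-methoxyphenyl on an aromatic carbon. Among the compounds with values here, the only measured step, a number 0.9 percentage points higher from compound 1 to compound 2 (within the scatter), concerns a different change and stayed within the scatter, so nothing measured bears directly on this swap. Compound 3 is therefore expected to show a step of a number 4.2 percentage points lower from compound 2 to compound 3 (within the scatter), staying close to compound 2. Compound 3 is estimated at 95%, between 80% and 105%.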

Compound 3, a percentage reported as activity, at one concentration (the size of the read-out at that concentration, not a potency): 99.5%
The estimate for compound 3 lay 4.5 percentage points below the measured number; measured number inside the range.
By their numbers in this assay, from the lowest: compounds 1, 2 and 3 (each within the scatter of the next).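

Compound 1 and compound 2 differ only in a substituent on the aryl ring, whereas compound 3 replaces the arm itself, bringing a double bond outside the aromatic rings. Even so, this assay shows a number 0.3 percentage points higher from compound 2 to compound 3 (within the scatter) and a number 1.2 percentage points higher from compound 1 to compound 3 (within the scatter), so this position tolerates either arm without a readable change in this read-out. No evidence is available that explains this result.

Going by these compounds, whether an amine or a carboxylic acid on this aromatic carbon would shift the number remains open. So does the effect of these arms at other concentrations.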